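The source may hold more compounds than are shown below. What is called first, only, known or untested is meant among the compounds shown, and "the series" means these compounds.

Compound 3 `O=C(C1CC(F)C1)N1CCc2nc(C#Cc3ccccc3)sc2C1` carries a (3-fluorocyclobutyl)carbonyl group on the amine nitrogen in a ring of the shared core. In an assay on HEK293 cells for positive allosteric modulation of metabotropic glutamate receptor 5 (Homo sapiens), read by FLIPR, with a stated time of 1 h (a lower number here means that less compound is needed, a higher number that more compound is needed for the effect), compound 3 gives 85 nM. Compound 1 `CCCCN1CCc2nc(C#Cc3ccccc3)sc2C1`, which has a butyl group at that same nitrogen, gives 110 nM in this assay, and the step of a 1.3-fold lower number from compound 1 to compound 3 (0.11 log units; within the scatter) shows that the two compounds lie close together. Compound 2 `CC(C)CN1CCc2nc(C#Cc3ccccc3)sc2C1` bears an isobutyl group there. For compound 2 this assay reports only a limit of the assay, > 10000 nM. Because of the limit of > 10000 nM in this assay, at which 1 of the 3 values shown sits, the steps that involve compound 2 can only be stated as minimum sizes. Those steps, an at least 90-fold higher number from compound 1 to compound 2 (1.95 log units; beyond the scatter) and an at least 110-fold lower number from compound 2 to compound 3 (2.07 log units; beyond the scatter), are both large, so within these three compounds the group on the ring nitrogen has a strong effect on the number.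

Compound 4 `O=C(c1cccc(Cl)c1)N1CCc2nc(C#Cc3ccccc3)sc2C1` differs from compound 3 by 3-chlorophenyl in place of 3-fluorocyclobutyl on a carbonyl carbon. Within the data shown here, none of the measured steps alters the group on the carbonyl carbon, so they bear on this change only indirectly, by showing that an amide built from a small ring is well tolerated. For compound 4 a step of a 1.2-fold higher number from compound 3 to compound 4 (0.07 log units; within the scatter) is expected, which means an estimated value of 100 nM, with a range from 25 nM to 600 nM.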

Compound 4, half-maximal effective concentration: 8.7 nM
Beside the measured number, compound 4's estimate is 11-fold (1.06 log units) above it; measured number outside the range, below it.
By their numbers in this assay, from the lowest: compound 4; then compounds 3 and 1 (each within the scatter of the next). At a limit, above all of these: compound 2.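

With the amide kept in place, the group on the carbonyl carbon still has a clear effect on the number: 3-chlorophenyl in place of 3-fluorocyclobutyl gives a 9.8-fold lower number from compound 3 to compound 4 (0.99 log units; beyond the scatter) in this assay. The earlier compounds shown here showed that an amide built from a small ring can be tolerated, whereas this step shows that the group carried by the carbonyl matters in its own right, and that here an aromatic ring bearing chlorine needs less compound than a fluorinated four-membered ring. Nothing measured here explains why the two groups differ.

The compounds shown leave open whether the chlorine contributes or the aromatic ring alone accounts for the step, which a plain phenyl group would test. On these data alone, how a pyridine ring or a methoxyphenyl group on the carbonyl carbon would read also remains unknown.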